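Adding an Acetamide to the Phenylethylamine Side Chain

The source may report more compounds than this note shows. Statements on the series, on what has been measured and on what is new or still open speak of the compounds shown alone.

Compound 1 `CN(CC1CCN(CCCc2c[nH]c3ccc(-n4cnnc4)cc23)CC1)C(=O)Nc1ccccc1` gives 5.9 nM
Compound 2 `C[C@@H](NCC1CCN(CCCc2c[nH]c3ccc(-n4cnnc4)cc23)CC1)c1ccccc1` gives 1.4 nM
Compound 3 `O[C@H]1Cc2ccccc2C1NC1CCN(CCCc2c[nH]c3ccc(-n4cnnc4)cc23)CC1` gives 37 nM

All three share a core and were tested in an assay on CHO cells for displacement of a labelled ligand from 5-hydroxytryptamine receptor 1D (Homo sapiens); on this read-out higher numbers stand for weaker inhibition and lower numbers for stronger inhibition. Compound 2 stands lowest: the step of a 4.2-fold lower number from compound 1 to compound 2 (0.62 log units; beyond the scatter) brings the number down, and the step of a 26-fold higher number from compound 2 to compound 3 (1.42 log units; beyond the scatter) raises it again sharply. Compound 4 `CC(=O)Nc1ccc([C@H](C)NCC2CCN(CCCc3c[nH]c4ccc(-n5cnnc5)cc34)CC2)cc1` differs from compound 2 in one place: 1-(4-acetamidophenyl)ethyl in place of 1-phenylethyl on an amine nitrogen. Neither measured step touches the aromatic ring itself; both alter the amine region and show that changes there can move the number a great deal. Here the ring and its chain stay, and only the acetamido group is added. The step from compound 2 to compound 4 is therefore expected to be small, a 1.4-fold higher number from compound 2 to compound 4 (0.15 log units; within the scatter) at most, within the scatter. Compound 4 is estimated at 2 nM, with a range from 0.5 nM to 8 nM in this assay.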

Compound 4, half-maximal inhibitory concentration: 0.6 nM
Estimate against measurement, compound 4: 3.3-fold (0.52 log units) above; the measured number falls inside the stated range.
By their numbers in this assay, from the lowest: compound 4; then compound 2; then compound 1; then compound 3.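

In this assay, replacing 1-phenylethyl with 1-(4-acetamidophenyl)ethyl on the amine nitrogen gives a 2.3-fold lower number from compound 2 to compound 4 (0.37 log units; beyond the scatter), a modest step beyond the scatter. The earlier steps shown here changed the amine region, whereas this one shows that the aromatic ring of the side chain can carry an acetamido group with no loss and a small gain. Nothing available here explains the lower number. From the compounds shown here alone, whether the amide hydrogen matters remains open, as does whether an amine or a carboxylic acid in place of the acetamido group would move the number the same way.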